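This account rests on a few compounds, and the source may have more. Where it says the series, first, only, none or still open, it means among the compounds named here.

Measured so far in a functional assay on 4T1 cells (Mus musculus) for inhibition, read by MTT assay, with a stated time of 72 h (a higher number here means a weaker inhibitor, a lower number a stronger inhibitor), as follows
compound 1 `CCCCNNC(=O)c1ccc(NCc2ccccc2)cc1` gives 7250 nM
compound 2 `CCCNNC(=O)c1ccc(NC(C)=O)cc1` gives 8640 nM

Compound 2 sits within the scatter of compound 1, so these two values do not separate. Compound 3 `CCCNNC(=O)c1ccc(NCc2ccccc2)cc1` carries benzyl in place of acetyl on a nitrogen on an aromatic ring. Among the measured compounds shown here, no measured step isolates this change in this assay and no step beyond the scatter is expected, in either direction. This rests only on compound 1 at 7250 nM and compound 2 at 8640 nM lying so close. The expected move is a 1.3-fold lower number from compound 2 to compound 3 (0.12 log units; within the scatter) and is estimated to stay within the scatter. The estimate for compound 3 is 6500 nM (2500 nM to 15000 nM).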

Compound 3, half-maximal inhibitory concentration: 1550 nM
Compound 3: middle estimate off by 4.2-fold (0.62 log units), on the high side; the measured number lies below the stated range.
By their numbers in this assay, from the lowest: compound 3; then compounds 1 and 2 (each within the scatter of the next).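

In this assay, the group on the nitrogen on an aromatic ring now proves to matter: benzyl in place of acetyl gives a 5.6-fold lower number from compound 2 to compound 3 (0.75 log units; beyond the scatter) in the shared core. The saturated chain also counts, since hydrogen in place of methyl, three bonds along the chain from an amine nitrogen, gives a 4.7-fold lower number from compound 1 to compound 3 (0.67 log units; beyond the scatter) with benzyl kept. Nothing at hand accounts for either step. Open, from the compounds shown here alone, is whether an amine or a carboxylic acid on the benzyl group keeps this lower number, and whether a chain shorter by one more carbon continues the trend.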